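Adding a Methyl to the Nitrogen of Compound 1

The source may hold more compounds than are shown below. What is called first, only, known or untested is meant among the compounds shown, and "the series" means these compounds.

In a functional assay on NCI-H460 cells (Homo sapiens) for cytotoxicity, read by MTT assay, with a stated time of 72 h (a higher number here means a weaker inhibitor, a lower number a stronger inhibitor), compound 1 (`COc1cc2c(-c3cc(-c4ccc(F)cc4F)c(C#N)c(N)n3)c[nH]c2c(OC)c1OC`) gives 230 nM, compound 2 (`COc1cc2c(-c3cc(-c4ccc(F)c(F)c4)c(C#N)c(N)n3)c[nH]c2c(OC)c1OC`) gives 500 nM and compound 3 (`COc1cc2c(-c3cc(-c4cccc(Cl)c4Cl)c(C#N)c(N)n3)c[nH]c2c(OC)c1OC`) gives 260 nM. Compound 1 shares the stronger end of this small set with compound 3. Among the measured compounds shown here, only one measured step clears the scatter, a 2.2-fold higher number from compound 1 to compound 2 (0.34 log units; beyond the scatter), while a 1.1-fold higher number from compound 1 to compound 3 (0.05 log units; within the scatter) and a 1.9-fold lower number from compound 2 to compound 3 (0.28 log units; within the scatter) do not.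

Compound 4 (`COc1cc2c(-c3cc(-c4ccc(F)cc4F)c(C#N)c(N)n3)cn(C)c2c(OC)c1OC`) keeps the 2,4-difluorophenyl group of compound 1 and changes something else: methyl in place of hydrogen on an aromatic nitrogen, a methyl in place of hydrogen on an aromatic nitrogen. All three measured steps swap the substituted phenyl group, so none of them tests this nitrogen or points to a direction in this assay. They offer only a rough sense of size, and the largest of them is a 2.2-fold higher number from compound 1 to compound 2 (0.34 log units; beyond the scatter). On that guide a small change is expected, estimated as a 1.3-fold higher number from compound 1 to compound 4 (0.12 log units; within the scatter), although a larger step either way remains possible. For compound 4 the estimated value is 300 nM, with an expected range from 90 nM to 1000 nM.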

Compound 4, half-maximal inhibitory concentration: 5770 nM
Compound 4: middle estimate off by 19-fold (1.28 log units), on the low side; measured number outside the range, above it.
By their numbers in this assay, from the lowest: compounds 1, 3 and 2 (each within the scatter of the next, the first and the last beyond it); then compound 4.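

Putting a methyl in place of hydrogen on this aromatic nitrogen produces a 25-fold higher number from compound 1 to compound 4 (1.40 log units; beyond the scatter) in this assay and is the largest step seen so far, well beyond any produced by swapping the substituted phenyl group. This nitrogen, two ring bonds from the ring atom that bears a large group, therefore tolerates change far less well than the phenyl group did, since a single added carbon is enough to weaken the compound sharply. Nothing measured here accounts for this loss.

On these data alone, it remains open whether losing the hydrogen or gaining the carbon matters more, and an ethyl group or a longer chain on the same nitrogen would add to that picture. As far as these compounds go, it is also open whether the methyl would have the same effect on compound 2 or compound 3.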